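Swapping the 2-hydroxypropyl group of compound 2

The source may report more compounds than this note shows. Statements on the series, on what has been measured and on what is new or still open speak of the compounds shown alone.

In an ADME assay on the whole organism (Mus musculus, strain ICR(CD-1)) for pharmacokinetics, read by mass spectrometry, at a dose of 10 mg/kg by the oral route (a lower number here means less compound in the circulation, a higher number more compound in the circulation at the dose given), compound 1 `Cc1ccc(C(=O)Nc2cccc(C(F)(F)F)c2)cc1-c1ccc2c(-c3cnn(C4CC4)c3)n[nH]c2c1`, with cyclopropyl on an aromatic nitrogen, gives 2240 nM. Among the measured compounds shown here, compound 2 `Cc1ccc(C(=O)Nc2cccc(C(F)(F)F)c2)cc1-c1ccc2c(-c3cnn(CC(C)O)c3)n[nH]c2c1`, which carries 2-hydroxypropyl there on the same core, gives 389 nM, the lower of the two numbers measured so far.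

For the measured compounds named here, compound 3 `Cc1ccc(C(=O)Nc2cccc(C(F)(F)F)c2)cc1-c1ccc2c(-c3cnn(C4CCN(C)CC4)c3)n[nH]c2c1` keeps the shared core and changes only this group: 1-methylpiperidin-4-yl in place of 2-hydroxypropyl on an aromatic nitrogen. The new group is 1-methylpiperidin-4-yl in place of 2-hydroxypropyl on an aromatic nitrogen, and neither measured compound carries it. Going by the values given here, one measured step bears on the change, because it concerns the same aromatic nitrogen: a 5.8-fold lower number from compound 1 to compound 2 (0.76 log units; beyond the scatter). That step shows that a swap here can move this assay by a modest amount, but it gives no direction for a group not yet tested. The expected outcome is therefore a 1.5-fold higher number from compound 2 to compound 3 (0.19 log units; within the scatter), with no step beyond the scatter as the central expectation. A step as large as the measured one remains possible in either direction. Compound 3 is estimated at 600 nM, with an expected range from 150 nM to 2200 nM.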

Compound 3, maximal plasma concentration: 304 nM
Beside the measured number, compound 3's estimate is 2.0-fold (0.30 log units) above it; measured number inside the range.
By their numbers in this assay, from the lowest: compounds 3 and 2 (each within the scatter of the next); then compound 1.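

In this assay, the change from 2-hydroxypropyl to 1-methylpiperidin-4-yl gives a 1.3-fold lower number from compound 2 to compound 3 (0.11 log units; within the scatter), so two quite different groups on this aromatic nitrogen cannot be told apart. The entering group has 7 heavy atoms, a six-membered non-aromatic ring and 0 hydrogen-bond donors, while the leaving group has 4 heavy atoms, no ring and 1 hydrogen-bond donor, yet these differences come with no step beyond the scatter. Cyclopropyl now stands apart from both groups, since the second comparison with it gives a 7.4-fold lower number from compound 1 to compound 3 (0.87 log units; beyond the scatter), which shows that the earlier drop was not particular to 2-hydroxypropyl, although three compounds are too few to support a wider pattern and nothing measured here explains the result.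

The compounds shown leave open whether other small groups on this nitrogen, such as methyl or cyclobutyl, would stay close to cyclopropyl in this assay. They also leave open where a carboxylic acid, or a longer chain ending in a primary amine, would fall relative to these three compounds.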